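The source may report more compounds than this note shows. Statements on the series, on what has been measured and on what is new or still open speak of the compounds shown alone.

Compounds measured in an assay on isolated protein for binding affinity to histone acetyltransferase KAT2B (Homo sapiens), read by isothermal titration calorimetry; a lower number here means tighter binding, a higher number weaker binding:

Compound 1, `C=CCCn1c(N[C@@H]2C[C@H](c3ccccc3)CN(C)C2)nc2cc[nH]c2c1=O` — 3410 nM
Compound 2, `C=CCn1c(N[C@@H]2C[C@H](c3ccccc3)CN(C)C2)nc2cc[nH]c2c1=O` — 676 nM
Compound 3, `CN1C[C@H](Nc2nc3cc[nH]c3c(=O)n2C)C[C@H](c2ccc(O)cc2)C1` — 120 nM

Compound 2 sits between the other two in this assay: compound 1 gives a higher number than compound 2, and compound 3 gives a lower one, so compound 2 is the second highest of the three numbers shown, closer to compound 1 than to compound 3.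

The unmeasured compound is compound 4, `CC=CCn1c(N[C@@H]2C[C@H](c3ccccc3)CN(C)C2)nc2cc[nH]c2c1=O`. It differs from compound 2 by methyl in place of hydrogen on a double-bonded chain carbon bound to a double-bonded chain carbon, so the chain on the aromatic nitrogen goes from allyl to but-2-en-1-yl.

For the measured compounds named here, one measured step touches the same chain: a 5.0-fold lower number from compound 1 to compound 2 (0.70 log units; beyond the scatter), where the chain was shortened from allyl to vinyl. Compound 4 goes the other way, adding a carbon back to the chain, though at a different position than in compound 1. On that basis the number for compound 4 is expected to rise, by a step of about a 2.2-fold higher number from compound 2 to compound 4 (0.35 log units; beyond the scatter), likely beyond the scatter but smaller than the step seen between compound 1 and compound 2. Compound 4 is therefore estimated at 1500 nM in this assay, within a range of 500 nM to 4500 nM.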

Compound 4, dissociation constant: 3040 nM
Compound 4: middle estimate off by 2.0-fold (0.31 log units), on the low side; the range from low to high includes it.
By their numbers in this assay, from the lowest: compound 3; then compound 2; then compounds 4 and 1 (each within the scatter of the next).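

In this assay, the chain on the aromatic nitrogen proves sensitive to a single added methyl on a double-bonded chain carbon bound to a double-bonded chain carbon: the change from allyl to but-2-en-1-yl gives a 4.5-fold higher number from compound 2 to compound 4 (0.65 log units; beyond the scatter), a step of similar size to the one already seen between the other two chains, a 5.0-fold lower number from compound 1 to compound 2 (0.70 log units; beyond the scatter). Two different chains thus give results that cannot be told apart, with a 1.1-fold lower number from compound 1 to compound 4 (0.05 log units; within the scatter), so among these three compounds the allyl chain of compound 2 binds more tightly than both chains that carry an extra carbon, whether that carbon sits at the chain end as a methyl or elsewhere in the chain. The data offer no measured explanation for why either extra carbon weakens binding in this series.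

The compounds shown leave open whether a saturated propyl chain, a propargyl chain or a 2-methylallyl chain would keep the binding of compound 2 in this assay. They also leave open whether the same methyl step would hold with the hydroxyl group of compound 3 on the phenyl ring and a chain other than methyl on the aromatic nitrogen.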